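Swapping an imidazole for a lactam on a shared core

The source may hold more compounds than are shown below. What is called first, only, known or untested is meant among the compounds shown, and "the series" means these compounds.

Measured so far:
- compound 1 `Cc1nc(C(c2ccc(-c3ccc4cccc(F)c4c3)[nH]c2=O)C(C)C)[nH]c1C`: 0.268 h
- compound 2 `CCn1ncc2c(F)cc(-c3ccc(C(CC)(CC)c4ncn(C)n4)c(=O)[nH]3)cc21`: > 3 h

Within the data shown here, in an ADME assay on microsomes from liver (Homo sapiens) for metabolic stability (a lower number here means that the compound disappears faster, a higher number that the compound lasts longer), compound 1 gives 0.268 h, the only plain number among the two values shown. For compound 2 this assay returns only a limit, > 3 h, which is the limit of > 3 h in this assay, at which 1 of the 2 values shown sits, and not a measured number. Compound 2 differs from compound 1 in many places at once, so the two values say nothing about any single change.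

Compound 3 `CC(C)C(/C=C1\CCNC1=O)c1ccc(-c2ccc3cccc(F)c3c2)[nH]c1=O` has not yet been measured in this assay. It differs from compound 1 in one place: a group of 7 heavy atoms (5 carbon, 1 nitrogen, 1 oxygen; one five-membered non-aromatic ring with 1 hetero atom) in place of a group of 7 heavy atoms (5 carbon, 2 nitrogen; one five-membered aromatic ring with 2 hetero atoms), on a saturated chain carbon bound to an aromatic carbon and a saturated chain carbon. Among the measured compounds shown here, no measured pair shows the effect of this particular exchange, so the expectation rests on compound 1 alone. A modest lengthening of the half-life is estimated, giving an expected step of a 1.5-fold higher number from compound 1 to compound 3 (0.17 log units; within the scatter) that stays close to the usual scatter. Compound 3 is therefore expected to give about 0.4 h in this assay, with a plausible range from 0.15 h to 1.2 h.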

Compound 3, half-life: 0.713 h
The estimate for compound 3 lay 1.8-fold (0.25 log units) below the measured number, within the range that was stated.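

Among these compounds, compound 1 and compound 3 form the first pair here that differs in only one place, so this exchange can be read on its own in this assay: replacing the 4,5-dimethyl-1H-imidazol-2-yl group on a saturated chain carbon bound to an aromatic carbon and a saturated chain carbon gives a 2.7-fold higher number from compound 1 to compound 3 (0.42 log units; beyond the scatter). The two groups match in their counts of heavy atoms, hydrogen-bond donors and hydrogen-bond acceptors, and neither carries a net charge, so those counts alone do not set the half-life at this position. No measurement shown explains why the half-life changes with this exchange.

This single pair cannot separate the part played by the loss of the aromatic ring from that of the double bonds outside aromatic rings in the entering group. A fully saturated pyrrolidinone ring, an open-chain amide or a carboxylic acid at the same place would show whether the step depends on this exact group or extends to other replacements for the imidazole.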